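The compounds below may be only part of what the source reports. "The series", "measured", "known", "first", "only" and "open" are said of these compounds alone.

Measured compounds:
compound 1, `CC(C)(C)c1ccc(CNC(=O)NCCCCl)cc1`, 19000 nM
compound 2, `CC(C)(C)c1ccc(CNC(=O)CCCl)cc1`, 87000 nM

In a functional assay on HT-29 cells (Homo sapiens) for antiproliferative activity, with a stated time of 48 h (on this read-out lower numbers stand for stronger inhibition and higher numbers for weaker inhibition), compound 2 gives the higher of the two numbers, and its nearest neighbour is compound 1, which gives 19000 nM. Compound 3, `CC(C)(C)c1ccc(CNC(=O)CCCCl)cc1`, is not yet measured; it differs from compound 2 by chloromethyl in place of chloro on a saturated chain carbon, two bonds along the chain from a carbonyl carbon. Within the data shown here, no measured step matches this change. Among the measured compounds shown here, the only step recorded, a 4.6-fold higher number from compound 1 to compound 2 (0.66 log units; beyond the scatter), concerns the group on the carbonyl carbon and bears on it only indirectly. A step of a 1.7-fold lower number from compound 2 to compound 3 (0.24 log units; within the scatter) is therefore expected, with a wide spread. Compound 3 is estimated at 50000 nM in this assay, between 15000 nM and 150000 nM.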

Compound 3, half-maximal inhibitory concentration: 72000 nM
Beside the measured number, compound 3's estimate is 1.4-fold (0.16 log units) below it; the range from low to high includes it.
By their numbers in this assay, from the lowest: compound 1; then compounds 3 and 2 (each within the scatter of the next).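

In this assay, chloromethyl in place of chloro on the saturated chain carbon, two bonds along the chain from a carbonyl carbon, gives a 1.2-fold lower number from compound 2 to compound 3 (0.08 log units; within the scatter) and so leaves the read-out unresolved for this change. With the 3-chloropropyl chain now matched, the (3-chloropropyl)amino group on the carbonyl carbon still separates the compounds, as 3-chloropropyl in its place gives a 3.8-fold higher number from compound 1 to compound 3 (0.58 log units; beyond the scatter) in this comparison. On these data alone, whether a longer chain at this position, or an amine in place of the chloro, would move the number stays open. Nothing available explains either step.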